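Aryl swap on the ring nitrogen: notes toward compound 4

This account rests on a few compounds, and the source may have more. Where it says the series, first, only, none or still open, it means among the compounds named here.

Measured so far in an assay on isolated protein for inhibition of Apoptosis regulator Bcl-2 (Homo sapiens), read by fluorescence polarization; on this read-out higher numbers stand for weaker inhibition and lower numbers for stronger inhibition:
compound 1 `COc1ccccc1N1C(=O)/C(=C/c2ccc(OCc3ccc(C(=O)O)cc3)cc2)SC1=S`: 2000 nM
compound 2 `COc1ccccc1N1C(=O)/C(=C/c2cccc(OCc3ccc(C(=O)O)cc3)c2)SC1=S`: 1600 nM
compound 3 `COc1ccccc1N1C(=O)/C(=C/c2ccc(OCC(=O)Nc3ccc(C(=O)O)cc3)cc2)SC1=S`: 10000 nM

Compound 3 gives the highest number of the three; the step of a 5.0-fold higher number from compound 1 to compound 3 (0.70 log units; beyond the scatter) is beyond the scatter, and compound 2 stands further away still. Compound 4 `O=C(COc1ccc(/C=C2\SC(=S)N(c3ccc([N+](=O)[O-])cc3)C2=O)cc1)Nc1ccc(C(=O)O)cc1` differs from compound 3 in one place: 4-nitrophenyl in place of 2-methoxyphenyl on an amide-type nitrogen in a ring. For the measured compounds named here, no measured step touches this position; every measured compound carries the 2-methoxyphenyl group there, and the single step available concerns the chain instead. There is therefore no basis for expecting a step beyond the scatter, and the working expectation for compound 4 is a number close to that of compound 3, as no change at the digits printed from compound 3 to compound 4 (within the scatter). The estimate for compound 4 in this assay is 10000 nM, within a range of 3000 nM to 30000 nM.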

Compound 4, inhibition constant: > 10000 nM
Compound 4: no number, only a limit (the forecaster's own chance of this, stated with the estimate: 25%); the middle value lies on the limit itself.
By their numbers in this assay, from the lowest: compounds 2 and 1 (each within the scatter of the next); then compound 3.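

On the amide-type nitrogen in a ring, 4-nitrophenyl in place of 2-methoxyphenyl gives a number no lower from compound 3 to compound 4 (the limit leaves the size open) in this assay. For compound 4, > 10000 nM is a limit of the assay and not a number. This swap therefore brings no lower number, and the size of the step cannot be read because the read-out ends at a limit: the limit of > 10000 nM in this assay, at which 1 of the 4 values shown sits.

As far as these compounds go, how an unsubstituted phenyl on this nitrogen would read remains open. So does whether 4-nitrophenyl would give the same outcome on the chain of compound 1.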